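Replacing 4-(trifluoromethyl)phenyl with pyridin-2-yl in compound 2

A few compounds are considered here, and "the series" means these few. Any claim that something is new, unique, unknown or untested is made for them only; others in the source may bear on it.

In an ADME assay on Vero cells (Chlorocebus sabaeus) for cytotoxicity, read by MTT assay, with a stated time of 96 h (a higher number here means that more compound is tolerated, a lower number that less compound is tolerated), compound 1 (`C/C(=N\NC(N)=S)c1ccc2[nH]c(-c3ccc(C(F)(F)F)cc3)nc2c1`) gives 22000 nM. Compound 2 (`C/C(=N\NC(N)=S)c1ccc2c(c1)nc(-c1ccc(C(F)(F)F)cc1)n2C1CCCCC1`) gives > 100000 nM, which is a limit of this assay and not a number. Where compound 2 truly stands is therefore unknown, and any step away from it starts from that limit.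

Compound 3 (`C/C(=N\NC(N)=S)c1ccc2c(c1)nc(-c1ccccn1)n2C1CCCCC1`) keeps the cyclohexyl group of compound 2 but carries pyridin-2-yl in place of 4-(trifluoromethyl)phenyl on an aromatic carbon, between two ring nitrogen atoms: pyridin-2-yl in place of 4-(trifluoromethyl)phenyl on an aromatic carbon.

Among the compounds with values here, only one measured step bears on this change, and only indirectly: an at least 4.5-fold higher number from compound 1 to compound 2 (0.65 log units; beyond the scatter). Within the data shown here, that step concerns the cyclohexyl group, which compound 3 retains, and no measured step exchanges the group now being replaced. Its size therefore cannot be carried over directly. A small move toward a lower number in this assay is expected, and the result may well stay at the limit.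

The estimated step is an at least 1.2-fold lower number from compound 2 to compound 3 (0.09 log units; that floor lies within the scatter). For compound 3 the expected half-maximal cytotoxic concentration is 80000 nM, with an estimated range of 30000 nM to 150000 nM.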

Compound 3, half-maximal cytotoxic concentration: 20000 nM
Beside the measured number, compound 3's estimate is 4.0-fold (0.60 log units) above it; the whole stated range lies above it.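

In this assay, the group on the aromatic carbon between two ring nitrogen atoms turns out to count: with the cyclohexyl group held in place, pyridin-2-yl in place of 4-(trifluoromethyl)phenyl gives an at least 5.0-fold lower number from compound 2 to compound 3 (0.69 log units; beyond the scatter). Within the data shown here, the only earlier step concerned the aromatic nitrogen, an at least 4.5-fold higher number from compound 1 to compound 2 (0.65 log units; beyond the scatter), so compound 3 is the first to show that the number also moves with the group at this second position, and that the cyclohexyl group alone does not keep the reading of compound 2 at its limit. Compound 2 gives > 100000 nM, which is a limit of this assay and not a number.

How large the step truly is stays open, and it can be stated only as a floor because its starting point is that limit: the limit of > 100000 nM in this assay, at which 1 of the 3 values shown sits. The compounds shown also do not separate the departure of the trifluoromethyl group from the arrival of the ring nitrogen, and a plain phenyl group at this position would be needed to tell the two apart.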